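Flavone ether anilides in the antiproliferative read-out

The source may hold more compounds than are shown below. What is called first, only, known or untested is meant among the compounds shown, and "the series" means these compounds.

Compounds measured so far:
compound 1 `O=C(COc1ccc2c(=O)cc(-c3ccccc3)oc2c1)Nc1ccc2ccccc2c1` — > 10000 nM
compound 2 `O=C(COc1c(-c2ccccc2)oc2ccccc2c1=O)Nc1ccccc1` — > 10000 nM
compound 3 `O=C(COc1ccc2c(=O)cc(-c3ccccc3)oc2c1)Nc1ccccc1` — > 10000 nM

In a functional assay on NPC-TW01 cells (Homo sapiens) for antiproliferative activity, read by MTT assay, with a stated time of 72 h (on this read-out lower numbers stand for stronger inhibition of growth and higher numbers for weaker inhibition of growth), compound 3 gives only a limit, > 10000 nM, and not a number. Compound 1 likewise gives only a limit in this assay, > 10000 nM. Compound 2 also sits at a limit, > 10000 nM. Compound 3 therefore does not stand apart from either: all three values rest at the same limit, (the limit of > 10000 nM in this assay, at which 3 of the 3 values shown sit), and no ordering among them can be read.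

The next compound is compound 4 `O=C(COc1ccc2c(=O)cc(-c3ccccc3)oc2c1)Nc1ccc(F)cc1`. It differs from compound 3 by fluoro in place of hydrogen on an aromatic carbon. Among the compounds with values here, the only step that touches this anilide end of the series is the one from compound 1 to compound 3, a step that the two limits leave unreadable from compound 1 to compound 3, whose size the two limits hide. Nothing measured reports a change in this assay on the amide-type nitrogen substituent large enough to emerge from the limit, and fluoro on the phenyl is a smaller change than the exchange of naphthalen-2-yl for phenyl. The expected step from compound 3 to compound 4 is a step that the limit leaves unreadable from compound 3 to compound 4, that is, none beyond the scatter. Compound 4 is therefore estimated at 15000 nM in this assay, within a range from 5000 nM to 50000 nM, most likely reported again as a limit.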

Compound 4, concentration for 50% growth inhibition: > 10000 nM
Compound 4 was reported as a limit; the forecaster's own chance of this, stated with the estimate: 85%; the middle value is on the limit's open side.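

No new step can be read: the comparisons of compound 4 with compound 3 and compound 1 remain unreadable because every value rests at the same limit: the limit of > 10000 nM in this assay, at which 4 of the 4 values shown sit.

In this assay the compounds shown leave open whether any change to this series gives a number rather than a limit.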